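Chloro-substituted anilides versus the benzyl amide

The compounds below may be only part of what the source reports. "The series", "measured", "known", "first", "only" and "open" are said of these compounds alone.

Measured so far:
compound 1 `COc1ccc2c(=O)c(/C=C/C(=O)Nc3cccc(Cl)c3)coc2c1`: 11900 nM
compound 2 `COc1ccc2c(=O)c(/C=C/C(=O)NCc3ccccc3)coc2c1`: 33400 nM

Within the data shown here, in a functional assay on HeLa cells (Homo sapiens) for inhibition, read by MTT assay, with a stated time of 48 h (on this read-out higher numbers stand for weaker inhibition and lower numbers for stronger inhibition), compound 2 gives the higher of the two numbers, with compound 1 as its only neighbour; the step of a 2.8-fold higher number from compound 1 to compound 2 (0.45 log units; beyond the scatter) lies beyond the scatter. Compound 3 `COc1ccc2c(=O)c(/C=C/C(=O)Nc3ccccc3Cl)coc2c1` is not yet measured. It differs from compound 2 by 2-chlorophenyl in place of benzyl on an amide-type nitrogen. Among the measured compounds shown here, the one measured step bears on this change only in part, since it returns an aryl group to the amide nitrogen, though with the chlorine in another position. A lower number is therefore expected, of about the size seen before. Compound 3 is expected to give 14000 nM, with a range of 5000 nM to 40000 nM. The expected step is a 2.4-fold lower number from compound 2 to compound 3 (0.38 log units; beyond the scatter).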

Compound 3, half-maximal inhibitory concentration: 22400 nM
For compound 3 the middle estimate is 1.6-fold (0.20 log units) below the measured one; low and high end bracket the measured number.
By their numbers in this assay, from the lowest: compounds 1, 3 and 2 (each within the scatter of the next, the first and the last beyond it).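

In this assay, 2-chlorophenyl in place of benzyl on an amide-type nitrogen gives a 1.5-fold lower number from compound 2 to compound 3 (0.17 log units; within the scatter) and so does not repeat the clear separation of the earlier step, a 2.8-fold higher number from compound 1 to compound 2 (0.45 log units; beyond the scatter). Exchanging 3-chlorophenyl for 2-chlorophenyl gives a 1.9-fold higher number from compound 1 to compound 3 (0.27 log units; within the scatter) and so sets no order between these two anilides. Nothing at hand explains these numbers.

Open, on these data alone, is how an unsubstituted phenyl group or a longer chain such as phenethyl would read at this nitrogen. Also open, as far as these compounds go, is whether a methyl group on this nitrogen would leave the number unchanged.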